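A few compounds are considered here, and "the series" means these few. Any claim that something is new, unique, unknown or untested is made for them only; others in the source may bear on it.

Compounds measured so far:
compound 1, `CCC(CC)c1cc(/C=C/c2cc(O)cc(O)c2)ccc1O` — 432 nM
compound 2, `CCC(CC)c1cc(/C=C/c2cc(O)cc(O)c2)cc(C(CC)CC)c1O` — 30 nM
compound 3, `CCC(CC)c1cc(/C=C/C=C/c2cc(O)cc(O)c2)ccc1O` — 79 nM

In a functional assay on HT-22 cells (Mus musculus), read by MTT assay, with a stated time of 24 h (on this read-out higher numbers stand for an effect only at larger amounts of compound and lower numbers for an effect already at smaller amounts), compound 1 gives 432 nM. Compound 2 differs from it by one change, (pentan-3-yl in place of hydrogen on an aromatic carbon), and this change gave a 14-fold lower number from compound 1 to compound 2 (1.16 log units; beyond the scatter). Compound 3 carries a different core; how its core differs from that of compound 1 is not broken down here. In this assay compound 3 gives 79 nM, a lower number than compound 1 shows, and a higher number than compound 2 shows.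

Compound 4, `CCC(CC)c1cc(/C=C/C=C/c2cc(O)cc(O)c2)cc(C(CC)CC)c1O`, has not yet been measured. It stands to compound 3 as compound 2 stands to compound 1: the change is pentan-3-yl in place of hydrogen on an aromatic carbon, and the place is the same in every respect. Going by the values given here, on the strength of the step from compound 1 to compound 2, a step of a similar size is expected in this assay from compound 3 to compound 4, that is a 9.9-fold lower number from compound 3 to compound 4 (0.99 log units; beyond the scatter), though with only one earlier example of the change the size is uncertain. For compound 4 the estimate in this assay is 8 nM, within the range 3 nM to 30 nM.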

Compound 4, half-maximal effective concentration: 12 nM
The estimate for compound 4 lay 1.5-fold (0.18 log units) below the measured number, and the stated range covers the measured number.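

The change of pentan-3-yl in place of hydrogen on an aromatic carbon, ortho to a hydroxy group, gave a 6.6-fold lower number from compound 3 to compound 4 (0.82 log units; beyond the scatter) in this assay, so it moved the number in the same direction on the second core as on the first. Set side by side, the two steps cannot be told apart in size: the same change on two cores in this assay, a 14-fold lower number (1.16 log units; beyond the scatter) from compound 1 to compound 2 and a 6.6-fold lower number (0.82 log units; beyond the scatter) from compound 3 to compound 4, 2.2-fold (0.34 log units) apart, within the scatter of two such steps. This shows that, across these two cores, the change carried over with its direction kept and with no difference in size that stands clear of the scatter, but two examples in a single assay do not show that it would carry to any other core, nor do they explain why it acts as it does.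

The compounds shown leave open whether another group in the same place, such as an ethyl group, a longer chain, an amine or a carboxylic acid, would give a similar step. They also leave open whether the step would hold with the hydroxy groups replaced by methoxy groups.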